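Replacing one side group in compound 1: solubility outlook

This account rests on a few compounds, and the source may have more. Where it says the series, first, only, none or still open, it means among the compounds named here.

Of the compounds shown here, three built on one shared core have been measured in a physicochemical assay for solubility, read by spectrophotometry, in phosphate buffer, with a stated time of 2 h, at pH 7.4; on this read-out higher numbers stand for higher solubility and lower numbers for lower solubility. Compound 1 `COc1ccc2[nH]c(C(=O)N3CC(=O)N(Cc4ccccc4)[C@@H](CN4CCC5(CC4)CC5)C3)cc2c1` gives 28200 nM. Compound 2 `COc1ccc2[nH]c(C(=O)N3CC(=O)N(Cc4cccc(OC)n4)[C@@H](Cc4ccccc4)C3)cc2c1` gives 47500 nM, and compound 3 `COc1cccc(CN2C(=O)CN(C(=O)c3cc4cc(OC)ccc4[nH]3)C[C@@H]2CCc2ccccc2)c1` gives 5100 nM. Among these three numbers compound 1 stands second highest; its number and that of compound 2 lie within the scatter of each other, so no order between the two is claimed, while the number of compound 3 lies beyond the scatter below compound 1.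

Compound 4 `COc1ccc2[nH]c(C(=O)N3CC(=O)N(Cc4ccccc4)[C@@H](COc4ccc(F)cc4)C3)cc2c1` has not yet been measured. It differs from compound 1 in a single place: a group of 8 heavy atoms (6 carbon, 1 oxygen, 1 fluorine; one six-membered aromatic ring of carbon only) in place of a group of 8 heavy atoms (7 carbon, 1 nitrogen; one three-membered non-aromatic ring of carbon only, one six-membered non-aromatic ring with 1 hetero atom), on a saturated chain carbon bound to a saturated ring carbon. Among the measured compounds shown here, no measured pair shows this exact change, so the size of the step has to be judged from the spread of the three numbers seen so far. The expected outcome in this assay is a step downward that goes beyond the scatter, a 3.5-fold lower number from compound 1 to compound 4 (0.55 log units; beyond the scatter). The estimate for compound 4 is 8000 nM, expected to fall between 3000 nM and 25000 nM.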

Compound 4, solubility: 17500 nM
Beside the measured number, compound 4's estimate is 2.2-fold (0.34 log units) below it, within the range that was stated.
By their numbers in this assay, from the lowest: compound 3; then compounds 4, 1 and 2 (each within the scatter of the next, the first and the last beyond it).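

In this assay, putting 4-fluorophenoxy in place of the nitrogen-bearing group on this saturated chain carbon gives a 1.6-fold lower number from compound 1 to compound 4 (0.21 log units; within the scatter), so this exchange of two groups of equal heavy-atom count cannot be told apart from repeat-measurement scatter. Among the compounds shown here, the earlier compounds offered no pair differing in one place, and this is the first direct reading at this position: a single aromatic ring of carbon only, in place of two non-aromatic rings, leaves no difference beyond the scatter. No measurement at hand explains why the two groups read alike.

On these data alone, whether a carboxylic acid or a plain longer carbon chain at this place would also stay within the scatter remains open. Also open, as far as these compounds go, is whether this same exchange would read alike on a compound carrying a different group elsewhere on the shared core, which one pair cannot show.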